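Cyclopropyl-to-propyl ketone swap carried onto the thiophene core

The compounds below may be only part of what the source reports. "The series", "measured", "known", "first", "only" and "open" are said of these compounds alone.

Compound 1 `CC1=C(C(=O)C2CC2)C(c2ccoc2)NC(=O)N1` gives 10% in an assay on membranes from HEK293 cells for displacement of a labelled ligand from adenosine receptor A2b (Homo sapiens), read by scintillation counting, with a stated time of 30 min, tested at 1 uM; on this read-out higher numbers stand for more inhibition at the one concentration tested (going by the name of the read-out) and lower numbers for less inhibition. Compound 2 `CCCC(=O)C1=C(C)NC(=O)NC1c1ccoc1` differs from compound 1 by propyl in place of cyclopropyl on a carbonyl carbon; in this assay compound 2 gives 22%, a step of a number 12 percentage points higher from compound 1 to compound 2 (beyond the scatter). Compound 3 `CC1=C(C(=O)C2CC2)C(c2ccsc2)NC(=O)N1` differs from compound 1 by thiophen-3-yl in place of furan-3-yl on a saturated ring carbon; in this assay compound 3 gives 1%, a step of a number 9 percentage points lower from compound 1 to compound 3 (within the scatter), so the two cores are not told apart by the data. Compound 4 `CCCC(=O)C1=C(C)NC(=O)NC1c1ccsc1` is not yet measured. It differs from compound 3 by propyl in place of cyclopropyl on a carbonyl carbon, the same change, at the same place, as that from compound 1 to compound 2. For the measured compounds named here, the step from compound 3 to compound 4 is expected to be a number 12 percentage points higher from compound 3 to compound 4 (beyond the scatter), resting only on the single earlier step of a number 12 percentage points higher from compound 1 to compound 2 (beyond the scatter). Compound 4 is therefore estimated at 13% in this assay.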

Compound 4, a percentage reported as inhibition, at one concentration (the size of the read-out at that concentration, not a potency): 9%
Beside the measured number, compound 4's estimate is 4 percentage points above it; low and high end bracket the measured number.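

Propyl in place of cyclopropyl gives a number 8 percentage points higher from compound 3 to compound 4 (within the scatter) in this assay, and this step is not told apart from the one on the furan-3-yl compounds: the same change on two cores in this assay, a number 12 percentage points higher (beyond the scatter) from compound 1 to compound 2 and a number 8 percentage points higher (within the scatter) from compound 3 to compound 4, 4 percentage points apart, within the scatter of two such steps. Thiophen-3-yl in place of furan-3-yl gives a number 13 percentage points lower from compound 2 to compound 4 (beyond the scatter) with the propyl ketone, and this step is likewise not told apart from the one with the cyclopropyl ketone: the same change on two cores in this assay, a number 9 percentage points lower (within the scatter) from compound 1 to compound 3 and a number 13 percentage points lower (beyond the scatter) from compound 2 to compound 4, 4 percentage points apart, within the scatter of two such steps. Both changes therefore carry over within the scatter across these four compounds, but one pair per change does not show that they would carry over to any other core.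

Open, going by these compounds, is how a longer chain such as pentyl, or an amine on the carbonyl carbon, would read. Also open, on these data alone, is whether phenyl in place of furan-3-yl or thiophen-3-yl would follow the same steps.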